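Changing the outer ring of a diaryl urea

A few compounds are considered here, and "the series" means these few. Any claim that something is new, unique, unknown or untested is made for them only; others in the source may bear on it.

Of the compounds shown here, three sharing one core have been tested in a functional assay on DU-145 cells (Homo sapiens) for inhibition, read by sulforhodamine B assay, with a stated time of 48 h, tested at 10 uM; a higher number here means a weaker effect of the compound at the concentration tested, a lower number a stronger effect. Compound 1 `COc1cc2cc(Oc3ccc(NC(=O)Nc4ccc(C)cc4)cc3)c(C)nc2cc1OC` gives 102%, compound 2 `COc1cc2cc(Oc3ccc(NC(=O)Nc4ccc(C(F)(F)F)cc4)cc3)c(C)nc2cc1OC` gives 71.4%, and compound 3 `COc1cc2cc(Oc3ccc(NC(=O)Nc4cccc(C(F)(F)F)c4)cc3)c(C)nc2cc1OC` gives 26.7%, the lowest of the three numbers and therefore the strongest effect seen so far. The measured steps are all large: a number 30.6 percentage points lower from compound 1 to compound 2 (beyond the scatter), a number 75.3 percentage points lower from compound 1 to compound 3 (beyond the scatter) and a number 44.7 percentage points lower from compound 2 to compound 3 (beyond the scatter). Together they show that the group on the outer ring of the urea, and where it sits, moves the number by wide margins.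

Compound 4 `COc1cc2cc(Oc3ccc(NC(=O)Nc4ccc(Cl)c(Cl)c4)cc3)c(C)nc2cc1OC` has not yet been measured. The change from compound 3 is 3,4-dichlorophenyl in place of 3-(trifluoromethyl)phenyl on an amide-type nitrogen. Among the measured compounds shown here, none of the measured steps involves a dichlorophenyl, so they give only a rough guide: the new ring keeps a substituent at the 3-position, which in compound 3 accompanied the lowest number, but adds a second chlorine. The expected step is therefore small, a number 6.3 percentage points higher from compound 3 to compound 4 (within the scatter), with a wide range. Compound 4 is estimated at 33%, between 10% and 70%.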

Compound 4, a percentage reported as activity, at one concentration (the size of the read-out at that concentration, not a potency): 24.8%
The estimate for compound 4 lay 8.2 percentage points above the measured number; the range from low to high includes it.
By their numbers in this assay, from the lowest: compounds 4 and 3 (each within the scatter of the next); then compound 2; then compound 1.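

Putting 3,4-dichlorophenyl in place of 3-(trifluoromethyl)phenyl on the amide-type nitrogen gives a number 1.9 percentage points lower from compound 3 to compound 4 (within the scatter) in this assay, so a low number at this position does not depend on trifluoromethyl. The same ring also stands well apart from the two rings with a lone group named at the 4-position, with a number 46.6 percentage points lower from compound 2 to compound 4 (beyond the scatter) and a number 77.2 percentage points lower from compound 1 to compound 4 (beyond the scatter), so two quite different outer rings now reach a similarly low number. Nothing at hand explains these differences.

The compounds shown leave open whether each chlorine of compound 4 is needed, which a 3-chlorophenyl or a 4-chlorophenyl ring would test, and whether a methoxy group or an amine on the ring could serve as well. A read-out at one concentration also leaves the potency of compound 3 and compound 4 unknown.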